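This account rests on a few compounds, and the source may have more. Where it says the series, first, only, none or still open, it means among the compounds named here.

Working notes on the series. Compound 1 `CCCCC/C=C\C[C@@]1(O)C=C(Cl)C(=O)/C1=C\C=C\CCCC(=O)OC` is the reference point; in a functional assay on PC-3 cells (Homo sapiens) for cytotoxicity, read by sulforhodamine B assay, with a stated time of 72 h (on this read-out lower numbers stand for stronger inhibition and higher numbers for weaker inhibition), compound 1 gives 800 nM. For the measured compounds named here, compound 2 `CCCCC/C=C\C[C@]1(OC(C)=O)C=CC(=O)/C1=C/C=C/CCCC(=O)OC` is the only other measured member, and in this assay compound 2 gives 3500 nM, a higher number than compound 1 and beyond the scatter, so compound 1 stands at the lowest number of the two measured. Compound 3 `CCCCC/C=C\C[C@@]1(O)C=C(I)C(=O)/C1=C\C=C\CCCC(=O)OC` has not been measured. It differs from compound 1 in one place: iodo in place of chloro on a double-bonded ring carbon. Going by the values given here, no measured pair in the set shares this change, so nothing about its size can be read from the numbers at hand. Among the compounds with values here, with no measured example of the change, the step of a 1.3-fold lower number from compound 1 to compound 3 (0.12 log units; within the scatter) is expected to be small, within the scatter or at most a modest move to a lower number. Compound 3 is therefore estimated at 600 nM in this assay, with a range from 200 nM to 2000 nM.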

Compound 3, half-maximal inhibitory concentration: 6700 nM
Beside the measured number, compound 3's estimate is 11-fold (1.05 log units) below it; the whole stated range lies below it.
By their numbers in this assay, from the lowest: compound 1; then compounds 2 and 3 (each within the scatter of the next).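

At this position the halogen matters: in this assay, iodo in place of chloro on the double-bonded ring carbon gives an 8.4-fold higher number from compound 1 to compound 3 (0.92 log units; beyond the scatter), a move beyond the scatter. The exchange replaces one heavy atom with one heavy atom and leaves the counts of hydrogen-bond donors and acceptors and the net charge unchanged, so these counts do not separate compound 1 from compound 3. No measurement in hand accounts for the size of this step.

On these data alone, only chloro and iodo can be read at this ring carbon, so it remains open where bromo, fluoro or a methyl group would fall in this assay. As far as these compounds go, it also remains open whether an amine or a longer chain at the same carbon would be tolerated, and whether any group there gives a lower number than chloro.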